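The compounds below may be only part of what the source reports. "The series", "measured", "known", "first", "only" and "open" are said of these compounds alone.

Three compounds here have been examined in an in vitro ADME assay on microsomes from liver (Rattus norvegicus) for metabolic stability, with a stated time of 30 min; a lower number here means slower removal, a higher number faster removal of the compound. Compound 1, with the structure `COc1ccccc1C(=O)NC(=O)Nc1ccc(-c2ccccc2)c(C(C)C)c1`, gives only a limit of the assay, namely < 14 mL.min-1.g-1. Compound 3, with the structure `COc1ccncc1C(=O)NC(=O)Nc1ccc(-c2ccccc2)c(C(F)(F)F)c1`, likewise gives only a limit, < 14 mL.min-1.g-1. Going by the values given here, compound 2, with the structure `COc1ccccc1C(=O)NC(=O)Nc1ccc(-c2ccccn2)c(C(F)(F)F)c1`, is the one compound whose result is an actual number: in this assay compound 2 gives 15 mL.min-1.g-1. That number sits close to the limit of < 14 mL.min-1.g-1 in this assay, at which 2 of the 3 values shown sit, so compound 2 is cleared slowly, and it cannot be ranked against the other two.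

Compound 4, with the structure `COc1ccccc1C(=O)NC(=O)Nc1ccc(N2CCCCC2)c(C(F)(F)F)c1`, is not yet measured. It differs from compound 2 in one place: piperidin-1-yl in place of pyridin-2-yl on an aromatic carbon. Among the compounds with values here, no measured pair shows what such a change does to the read-out, so the expectation rests on compound 2 alone. In this assay compound 4 is expected to give 25 mL.min-1.g-1, with a likely range from 12 mL.min-1.g-1 to 60 mL.min-1.g-1. The step this implies, a 1.7-fold higher number from compound 2 to compound 4 (0.22 log units; within the scatter), is estimated to be modest, upward in direction but not clearly beyond the usual scatter.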

Compound 4, intrinsic clearance in microsomes: 26 mL.min-1.g-1
For compound 4 the middle estimate is 1.0-fold (0.02 log units) below the measured one, and the stated range covers the measured number.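

Going by these compounds alone, compound 2 and compound 4 form the first measured pair here that differs in only one place, so a change on this aromatic carbon, ortho to a trifluoromethyl group, can now be read directly in this assay. Putting the non-aromatic piperidin-1-yl in place of the aromatic pyridin-2-yl, with the same count of heavy atoms, gives a 1.7-fold higher number from compound 2 to compound 4 (0.24 log units; within the scatter), so in this pair losing the aromatic ring does not move the read-out beyond the scatter. Little of the scale remains at the low end for reading such steps: the limit of < 14 mL.min-1.g-1 in this assay, at which 2 of the 4 values shown sit.

The compounds shown leave open whether a morpholin-4-yl ring or an open-chain dimethylamino group at this position would also stay within the scatter of compound 2. They also leave open whether the same exchange would give a similar step with isopropyl in place of trifluoromethyl.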